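The compounds below may be only part of what the source reports. "The series", "measured", "known", "first", "only" and "open" are said of these compounds alone.

Compound 1 `N#Cc1c(-c2ccc3c(ccn3CC3CC3)c2)ccn2c(CC(F)(F)F)cnc12` was examined in a functional assay on CHO cells for agonist activity at metabotropic glutamate receptor 2 (Homo sapiens), read by GTPgammaS binding (a higher number here means that more compound is needed for the effect, a lower number that less compound is needed), where compound 1 gives 190 nM. Among the three compounds measured, compound 1 stands second highest. The nearest number belongs to compound 3 `N#Cc1c(-c2cc(Cl)c3c(ccn3CC3CC3)c2)ccn2c(CC(F)(F)F)cnc12`, which in this assay gives 110 nM; the step of a 1.7-fold lower number from compound 1 to compound 3 (0.24 log units; within the scatter) lies within the scatter. The furthest number belongs to compound 2 `N#Cc1c(-c2ccc3c(c2)OCCN3)ccn2c(CC(F)(F)F)cnc12`, which in this assay gives 1660 nM; compound 2 differs from compound 1 in more than one place, so its number can only be set beside that of compound 1 without a counted step.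

Compound 4 `N#Cc1c(-c2ccc3c(ccn3C3CCOCC3)c2)ccn2c(CC(F)(F)F)cnc12` has not yet been measured. It differs from compound 1 by oxan-4-yl in place of cyclopropylmethyl on an aromatic nitrogen. Going by the values given here, none of the measured steps touches this part of the molecule: the single counted step concerns a chloro on an aromatic carbon and leaves the group on the aromatic nitrogen unchanged, while compound 2 alters the fused ring itself. No size or direction can therefore be read from the measured steps, and compound 1 remains the only anchor. For compound 4 a number close to that of compound 1 is expected, with a wide range, namely 250 nM (70 nM to 900 nM). The expected step of a 1.3-fold higher number from compound 1 to compound 4 (0.12 log units; within the scatter) is accordingly small, though the range allows a change in either direction.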

Compound 4, half-maximal effective concentration: 501 nM
For compound 4 the middle estimate is 2.0-fold (0.30 log units) below the measured one; the range from low to high includes it.
By their numbers in this assay, from the lowest: compounds 3 and 1 (each within the scatter of the next); then compound 4; then compound 2.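

Going by these compounds alone, the result adds a 2.6-fold higher number from compound 1 to compound 4 (0.42 log units; beyond the scatter) in this assay, the first counted step at the group on the aromatic nitrogen of the five-membered aromatic ring. Within the data shown here, the earlier counted step, a 1.7-fold lower number from compound 1 to compound 3 (0.24 log units; within the scatter), placed a chloro on an aromatic carbon and stayed within the scatter, so this nitrogen is the first place where a single change is seen to shift the number beyond it, though only modestly. Oxan-4-yl, with its six-membered non-aromatic ring and its hydrogen-bond acceptor, is thus a less favourable group here than cyclopropylmethyl, but nothing measured on these compounds explains the shift.

A single replacement changes the ring size, the heavy-atom count and the ring oxygen all at once, so the compounds shown do not separate these differences from one another. Cyclohexyl, an all-carbon six-membered ring, would stand closest to oxan-4-yl for that question, while piperidin-4-yl or a longer chain such as n-butyl on the same nitrogen leaves open how far the number moves with other groups at this place.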